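Swapping the sulfonamide cap on a quinoline thiourea series

The source may hold more compounds than are shown below. What is called first, only, known or untested is meant among the compounds shown, and "the series" means these compounds.

Of the compounds shown here, three that share one core have been tested in a functional assay on HepG2 cells (Homo sapiens) for antiproliferative activity, read by sulforhodamine B assay, with a stated time of 48 h; on this read-out higher numbers stand for weaker inhibition and lower numbers for stronger inhibition. Compound 1 `N=C(N)NS(=O)(=O)c1ccc(N/C(S)=N\c2ccnc3cc(C(F)(F)F)ccc23)cc1` gives 33500 nM in this assay; among the three numbers it stands second highest, with compound 2 nearest and compound 3 furthest, both within the scatter. Compound 2 `Cc1noc(NS(=O)(=O)c2ccc(N/C(S)=N\c3ccnc4cc(C(F)(F)F)ccc34)cc2)c1C` gives 36800 nM, and compound 3 `O=S(=O)(Nc1nccs1)c1ccc(N/C(S)=N\c2ccnc3cc(C(F)(F)F)ccc23)cc1` gives 28200 nM. Both differ from compound 1 only at the sulfonamide nitrogen, where a five-membered aromatic ring replaces the small open-chain group, and neither change moved the number beyond the scatter: a 1.1-fold higher number from compound 1 to compound 2 (0.04 log units; within the scatter) and a 1.2-fold lower number from compound 1 to compound 3 (0.07 log units; within the scatter). Between the two ring-bearing compounds the same holds: a 1.3-fold lower number from compound 2 to compound 3 (0.12 log units; within the scatter).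

Compound 4 `Cc1ccnc(NS(=O)(=O)c2ccc(N/C(S)=N\c3ccnc4cc(C(F)(F)F)ccc34)cc2)n1` has not been measured. It differs from compound 1 in the same place: a group of 7 heavy atoms (5 carbon, 2 nitrogen; one six-membered aromatic ring with 2 hetero atoms) in place of a group of 3 heavy atoms (1 carbon, 2 nitrogen; no ring), on a sulfonamide nitrogen. The two earlier steps at this position are the ones that bear on it, and both were too small to count, so the expected change is none beyond the scatter, with the estimate for compound 4 set by a 1.0-fold lower number from compound 1 to compound 4 (0.02 log units; within the scatter). Compound 4 is therefore estimated at 32000 nM, expected to fall between 15000 nM and 68000 nM.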

Compound 4, half-maximal inhibitory concentration: "not active" (no number reported)
The entry for compound 4 holds no number, so the estimate cannot be set against anything.
By their numbers in this assay, from the lowest: compounds 3, 1 and 2 (each within the scatter of the next).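

For the compounds shown here, compound 4 is recorded in this assay only as "not active", with no number, so no step from compound 1, compound 2 or compound 3 to compound 4 can be read. Nothing shown offers an explanation for this entry. The compounds shown leave open how 4-methylpyrimidin-2-yl on a sulfonamide nitrogen compares numerically with the groups in compounds 1, 2 and 3.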